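Double-bond geometry in a naphthalen-2-yl oxime ether

The compounds below may be only part of what the source reports. "The series", "measured", "known", "first", "only" and "open" are said of these compounds alone.

- compound 1 `O=C(O)CCC/C=C1/C[C@H]2C[C@@H](O)[C@H](/C=N/OCc3ccc(F)cc3)[C@H]2C1`: 14000 nM
- compound 2 `O=C(O)CCC/C=C1/C[C@H]2C[C@@H](O)[C@H](/C=N/OCc3ccc4ccccc4c3)[C@H]2C1`: 2200 nM
- compound 3 `O=C(O)CCC/C=C1/C[C@H]2C[C@@H](O)[C@H](/C=N/OCc3ccccc3)[C@H]2C1`: 5400 nM

These values come from a functional assay for agonist activity, with Homo sapiens as the target; a lower number here means a stronger inhibitor, a higher number a weaker inhibitor. Compound 2 has the lowest number of the three, with a 2.5-fold higher number from compound 2 to compound 3 (0.39 log units; beyond the scatter) and a 6.4-fold lower number from compound 1 to compound 2 (0.80 log units; beyond the scatter) separating it from the others. Compound 4 `O=C(O)CCC/C=C1\C[C@H]2C[C@@H](O)[C@H](/C=N/OCc3ccc4ccccc4c3)[C@H]2C1` alters it in one respect: the two compounds have the same atoms and bonds and differ only in configuration as drawn: 1 of 6 stereo elements differ; a double bond is drawn Z in compound 2 and E in compound 4. The measured steps exchange only 4-fluorophenyl, phenyl and naphthalen-2-yl, as in a 2.6-fold lower number from compound 1 to compound 3 (0.41 log units; beyond the scatter). All are modest, and none tests the double bond, so they offer only a loose guide to size and none to direction. Tentatively, the expected change is a 3.1-fold lower number from compound 2 to compound 4 (0.50 log units; beyond the scatter). For compound 4 the estimate is 700 nM, within an expected range of 80 nM to 4000 nM.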

Compound 4, half-maximal inhibitory concentration: 1600 nM
Estimate against measurement, compound 4: 2.3-fold (0.36 log units) below; measured number inside the range.
By their numbers in this assay, from the lowest: compounds 4 and 2 (each within the scatter of the next); then compound 3; then compound 1.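

In this assay the double bond itself is now tested, which the exchanges of 4-fluorophenyl, phenyl and naphthalen-2-yl could not do, and the change gives a 1.4-fold lower number from compound 2 to compound 4 (0.14 log units; within the scatter) with the naphthalen-2-yl oxime ether held constant. Drawn Z or E, this double bond thus makes no difference beyond the scatter in this pair. The comparison speaks to that double bond alone: the fact that compounds 2 and 4 differ only in the configuration as drawn.

As far as these compounds go, whether the same holds with phenyl or 4-fluorophenyl in place of naphthalen-2-yl stays open. So does the effect of an amide in place of the carboxylic acid.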